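A few compounds are considered here, and "the series" means these few. Any claim that something is new, unique, unknown or untested is made for them only; others in the source may bear on it.

Going by the values given here, compound 2 `CCCNCC(=O)N1N=C(c2cc3ccccc3oc2=O)CC1c1ccccc1` gives 7270 nM in a functional assay on PC-3 cells (Homo sapiens) for cytotoxicity, read by MTT assay, with a stated time of 48 h (on this read-out higher numbers stand for weaker inhibition and lower numbers for stronger inhibition), the higher of the two numbers measured so far, though the gap to compound 1 `O=C(c1ccccc1Cl)N1N=C(c2cc3ccccc3oc2=O)CC1c1ccccc1` with 6370 nM lies within the scatter. Compound 3 `CC1CCCN(CC(=O)N2N=C(c3cc4ccccc4oc3=O)CC2c2ccccc2)C1` differs from compound 2 by a single change: 3-methylpiperidin-1-yl in place of propylamino on a saturated chain carbon bound to a carbonyl carbon. Among the compounds with values here, the only measured step, a 1.1-fold higher number from compound 1 to compound 2 (0.06 log units; within the scatter), altered a different part of the molecule, the group attached directly to the carbonyl carbon, and that step stayed within the scatter. Within the data shown here, no measured step touches the propylamino group on the saturated chain carbon, so there is no direct guide for swapping it for a ring here. With both known numbers so close together, the expectation for compound 3 is a step of a 1.0-fold lower number from compound 2 to compound 3 (0.02 log units; within the scatter), small enough to stay within the scatter. The estimate for compound 3 in this assay is 7000 nM, within a range from 3000 nM to 16000 nM.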

Compound 3, half-maximal inhibitory concentration: 28300 nM
Compound 3: middle estimate off by 4.0-fold (0.61 log units), on the low side; measured number above the stated range.
By their numbers in this assay, from the lowest: compounds 1 and 2 (each within the scatter of the next); then compound 3.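

In this assay, the group on the saturated chain carbon bound to a carbonyl carbon clearly matters: 3-methylpiperidin-1-yl in place of propylamino gives a 3.9-fold higher number from compound 2 to compound 3 (0.59 log units; beyond the scatter) and so weakens the result beyond the scatter. The earlier swap on the carbonyl carbon stayed within the scatter, so those first two compounds gave no sign that this side of the molecule could move the number, yet the new side chain set against 2-chlorophenyl gives a 4.4-fold higher number from compound 1 to compound 3 (0.65 log units; beyond the scatter) in the same direction. Nothing measured here explains why the number rises.

The change adds a ring and a methyl group and also removes the hydrogen-bond donor, and these compounds cannot separate those differences. Piperidin-1-yl without the methyl, or an open-chain dipropylamino group, would help show which difference counts.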